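Shifting the methylpyrazole attachment point from compound 3 to compound 4

The source may report more compounds than this note shows. Statements on the series, on what has been measured and on what is new or still open speak of the compounds shown alone.

Compound 1 `CSc1cc(C)nc(SC)c1NC(=O)N(Cc1cccc(-c2cnn(C)c2)c1)C1CCCCCC1`: in a functional assay on a cell-free system (plasma) with sterol O-acyltransferase, Soat (Rattus norvegicus) as the target (a higher number here means that more compound is needed for the effect, a lower number that less compound is needed), compound 1 gives > 0.1 mg/kg, a limit of the assay.
Compound 2 `Cc1cc(C)c(NC(=O)N(Cc2cccc(-c3cn[nH]c3)c2)C2CCCCCC2)c(C)c1`: in this assay compound 2 gives 0.19 mg/kg.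
Compound 3 `Cc1cc(C)c(NC(=O)N(Cc2cccc(-c3ccnn3C)c2)C2CCCCCC2)c(C)c1`: in this assay compound 3 gives > 1 mg/kg, a limit of the assay.

Compound 3 thus stands at the limit of > 1 mg/kg in this assay, at which 1 of the 3 values shown sits, so only a lower bound is known for it; compound 1 likewise sits at the limit of > 0.1 mg/kg in this assay, at which 1 of the 3 values shown sits. Compound 4 `Cc1cc(C)c(NC(=O)N(Cc2cccc(-c3cnn(C)c3)c2)C2CCCCCC2)c(C)c1` differs from compound 3 by 1-methyl-1H-pyrazol-4-yl in place of 1-methyl-1H-pyrazol-5-yl on an aromatic carbon. Going by the values given here, the one measured step that bears on this change is an at least 5.2-fold higher number from compound 2 to compound 3 (0.72 log units; beyond the scatter), where the pyrazole attached through its 4-position gave the lower number and the 1-methyl-5-yl attachment gave a limit. Compound 4 returns to a 4-yl attachment while keeping the ring methyl, so the step from compound 3 to compound 4 is expected to run in the opposite direction to that measured step, with the estimated size an at least 3.3-fold lower number from compound 3 to compound 4 (0.52 log units; beyond the scatter). Because compound 2 gives 0.19 mg/kg, compound 4 is expected to land near that value, estimated at 0.3 mg/kg with a range from 0.1 mg/kg to 1 mg/kg.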

Compound 4, dose for half-maximal effect: < 1 mg/kg
Compound 4 was reported as a limit; the forecaster's own chance of this, stated with the estimate: 30%; the middle value is on the limit's open side.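

In this assay, exchanging 1-methyl-1H-pyrazol-5-yl for 1-methyl-1H-pyrazol-4-yl, with the same atoms joined differently, gives a number no higher from compound 3 to compound 4 (the limit leaves the size open); this isolates the attachment point on the aromatic carbon, whereas the earlier step changed the attachment and the methyl on the aromatic nitrogen together. Compound 4 is known only as a limit: the limit of < 1 mg/kg in this assay, at which 1 of the 4 values shown sits. The steps from compound 2 and from compound 1 to compound 4 cannot be read, and the methyl on the aromatic nitrogen therefore has no readable effect at the 4-yl attachment.

The compounds shown leave open where compound 4 lies under its limit and whether the two attachments truly differ in this assay. They also leave open how a longer chain on the pyrazole nitrogen, or a carboxylic acid in place of the pyrazole, would fare at this place.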